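The source may report more compounds than this note shows. Statements on the series, on what has been measured and on what is new or still open speak of the compounds shown alone.

Measured so far in an ADME assay on WI-38 cells (Homo sapiens) for cytotoxicity, read by MTT assay, with a stated time of 72 h; a higher number here means a weaker inhibitor, a lower number a stronger inhibitor:
- compound 1, `CN(C)CCn1cnnc1-c1cc(Oc2ccc(NC(=O)N/N=C/c3cc(C(C)(C)C)cc(C(C)(C)C)c3O)cc2F)ccn1`, gives 2350 nM
- compound 2, `COc1ccc(OC)c(/C=N/NC(=O)Nc2ccc(Oc3ccnc(-c4nncn4CCN(C)C)c3)c(F)c2)c1`, gives "not determined" (no result reported)
- compound 3, `COc1cc(/C=N/NC(=O)Nc2ccc(Oc3ccnc(-c4nncn4CCN(C)C)c3)c(F)c2)cc(OC)c1OC`, gives "not determined" (no result reported)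

Compound 3 stands without a single number in this assay; compound 2 is the further entry that likewise carries no single number. Among the compounds with values here, only compound 1 supplies a figure in this assay, so nothing measured anchors the position of compound 3, and no step between measured compounds can be read off.

Compound 4, `CN(C)CCn1cnnc1-c1cc(Oc2ccc(NC(=O)N/N=C/c3ccc(F)cc3Cl)cc2F)ccn1`, is the next member to be run in this assay. Relative to compound 3 the change is 2-chloro-4-fluorophenyl in place of 3,4,5-trimethoxyphenyl on a carbon with a double bond to nitrogen. Since compound 3 has no value, the step to compound 4 cannot be sized from the data in this assay; the only reference is the figure of compound 1, which shares the core with both. Absent any step to lean on, the expectation is that compound 4 will land in the same region as compound 1 rather than far from it, with wide uncertainty.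

Compound 4 is expected to give about 3000 nM in this assay, estimated within 800 nM to 12000 nM.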

Compound 4, half-maximal inhibitory concentration: 2090 nM
Compound 4: the middle estimate sits 1.4-fold (0.16 log units) above what was measured; the range from low to high includes it.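

No step can be read from compound 4, which gives 2090 nM in this assay, as compound 3 carries no single number there. No measured evidence bears on this result. The compounds shown leave open how far replacing 3,4,5-trimethoxyphenyl with 2-chloro-4-fluorophenyl shifts the read-out in this assay.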